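This account rests on a few compounds, and the source may have more. Where it says the series, first, only, none or still open, it means among the compounds named here.

Compound 1, `COc1ccccc1Oc1ccc2c(NCCCNCc3ccco3)ccnc2c1`, gives 9.28 in a physicochemical assay for acid dissociation.
Compound 2, `c1ccc(Oc2ccc3c(NCCCNCc4ccco4)ccnc3c2)cc1`, gives 9.28.
Compound 3, `Fc1ccc(Cc2ccc3c(NCCCNCc4ccco4)ccnc3c2)c(Cl)c1`, gives 9.47.

Compound 3 holds the highest of the three numbers, but only narrowly: the change a number 0.19 log units higher from compound 1 to compound 3 (within the scatter) and the change a number 0.19 log units higher from compound 2 to compound 3 (within the scatter) both fall within the scatter, and so does no change at the digits printed from compound 1 to compound 2 (within the scatter). Across these three compounds the group on the aromatic carbon of the shared core has been varied from a substituted phenoxy to a plain phenoxy to a benzyl bearing chlorine and fluorine, and the acid dissociation constant has barely moved.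

Compound 4, `COc1ccc(-c2ccc3c(NCCCNCc4ccco4)ccnc3c2)cc1`, is the next member of this set. Its difference from compound 3 is 4-methoxyphenyl in place of 2-chloro-4-fluorobenzyl on an aromatic carbon. The three steps already seen bear directly on this change, since each of them also swaps the group at this same aromatic carbon, and none of them reached beyond the scatter. The step this estimate means, a number 0.12 log units lower from compound 3 to compound 4 (within the scatter), is therefore expected to be small, with no clear direction. Compound 4 is expected to give about 9.35, within a range from 9.05 to 9.65.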

Compound 4, acid dissociation constant: 9.47
Compound 4: middle estimate off by 0.12 log units, on the low side; the range from low to high includes it.
By their numbers in this assay, from the lowest: compounds 1, 2, 3 and 4 (each within the scatter of the next).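

In this assay, the swap that removes 2-chloro-4-fluorobenzyl, with its chlorine and fluorine, and brings in 4-methoxyphenyl, with its oxygen and one hydrogen-bond acceptor, gives no change at the digits printed from compound 3 to compound 4 (within the scatter). The 4-methoxyphenyl group also stays within the scatter of both phenoxy compounds, with a number 0.19 log units higher from compound 2 to compound 4 (within the scatter) and a number 0.19 log units higher from compound 1 to compound 4 (within the scatter), so all four groups at this aromatic carbon, each with a six-membered aromatic ring of carbon only, now give numbers within the scatter of one another. Nothing available explains why the number holds so steady across these groups.

From the compounds shown here alone, whether a group without such a ring at this carbon, such as an amine or a carboxylic acid, would move the number beyond the scatter remains open. The compounds shown also cannot say what a longer chain in place of the one they all share would do.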